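Compound 3 in the monoamine oxidase B series: an expectation

The source may hold more compounds than are shown below. What is called first, only, known or untested is meant among the compounds shown, and "the series" means these compounds.

Compound 1, with the structure `CC(C)c1noc(-c2ccc(C3=NCCN3)cc2)n1`, is the reference point of this small set. In an assay for inhibition of Amine oxidase [flavin-containing] B (Homo sapiens), read by fluorescence and spectrophotometry, using microsomes, with stated times of 30 min and 20 min (on this read-out lower numbers stand for stronger inhibition and higher numbers for weaker inhibition), compound 1 gives 230 nM, the lowest of the two numbers available. The only companion, compound 2 with the structure `CC(C)(C)c1ccc(-c2noc(-c3ccc(C4=NCCN4)cc3)n2)cc1`, gives 411 nM in this assay, a gap from compound 1 that lies within the usual scatter, so the two cannot be ordered against each other.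

Compound 3, with the structure `Clc1ccccc1-c1noc(-c2ccc(C3=NCCN3)cc2)n1`, has not yet been measured. It differs from compound 1 by a single change, (2-chlorophenyl in place of isopropyl on an aromatic carbon). Among the measured compounds shown here, no step between two measured compounds corresponds to this change, so its size can only be guessed. Since the larger group of compound 2 left the number at 411 nM, close to that of compound 1, the account expects compound 3 to show no step beyond the scatter, with the estimated shift a 1.3-fold higher number from compound 1 to compound 3 (0.12 log units; within the scatter). Compound 3 is therefore expected to give about 300 nM in this assay, with a range from 100 nM to 900 nM.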

Compound 3, half-maximal inhibitory concentration: 30 nM
Beside the measured number, compound 3's estimate is 10-fold (1.00 log units) above it; measured number outside the range, below it.
By their numbers in this assay, from the lowest: compound 3; then compounds 1 and 2 (each within the scatter of the next).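

In this assay the change to 2-chlorophenyl in place of isopropyl, on the aromatic carbon between two ring nitrogen atoms, gives a 7.7-fold lower number from compound 1 to compound 3 (0.88 log units; beyond the scatter) and this step lies beyond the scatter. Compound 1 and compound 2 sit within the scatter of each other, so they showed no clear response to the group at this position, whereas compound 3 shows that the number can move with what stands there. No measurement shown accounts for this step.

The compounds shown leave open whether the step belongs to the aromatic ring of carbon or to its chlorine, which a plain phenyl group would help to separate. They also leave open how a methyl or methoxy group in place of that chlorine would read in this assay on this core.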